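Moving a methoxy group on the cinnamate aryl ring

The source may report more compounds than this note shows. Statements on the series, on what has been measured and on what is new or still open speak of the compounds shown alone.

Among the compounds with values here, the two compounds measured so far share a cinnamate ester linking two aromatic rings. In a functional assay on the whole organism (strain Kunming) with Mus musculus as the target, with a stated time of 0.5 h, at a dose of 300 mg/kg by the intraperitoneal route (on this read-out higher numbers stand for a weaker effect at the one dose given and lower numbers for a stronger effect), compound 1 `COc1cc(OC)c(OC)cc1/C=C/COC(=O)/C=C/c1ccc(OC)c(OC)c1OC` gives 25%. Compound 2 `COc1cc(OC)c(OC)cc1/C=C/COC(=O)/C=C/c1ccc(OC)c(OC)c1` differs in one place: a number 25 percentage points lower from compound 1 to compound 2 (beyond the scatter). In this assay compound 2 gives 0%, the lowest of the two numbers, and compound 1 stands above it by a step beyond the scatter.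

Compound 3 `COc1ccccc1/C=C/C(=O)OC/C=C/c1cc(OC)c(OC)cc1OC` is not yet measured. Compared with compound 2 it carries 2-methoxyphenyl in place of 3,4-dimethoxyphenyl on a double-bonded chain carbon bound to a double-bonded chain carbon. Within the data shown here, the only step known, from compound 1 to compound 2, removed one methoxy from this same ring and moved the number down. Here one methoxy is lost and the remaining one is shifted, so the direction is uncertain. Because compound 2 already gives 0%, the number cannot fall further. The expected step is a number 10 percentage points higher from compound 2 to compound 3 (within the scatter), within the scatter. Compound 3 is therefore estimated at 10%, with a range from 0% to 30%.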

Compound 3, a percentage reported as activity, at one dose (the size of the read-out at that dose, not a potency): 50%
Beside the measured number, compound 3's estimate is 40 percentage points below it; the measured number lies above the stated range.
By their numbers in this assay, from the lowest: compound 2; then compound 1; then compound 3.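

In this assay, 2-methoxyphenyl in place of 3,4-dimethoxyphenyl on a double-bonded chain carbon bound to a double-bonded chain carbon gives a number 50 percentage points higher from compound 2 to compound 3 (beyond the scatter), which on this read-out means a much weaker effect at the one dose given. The earlier step, a number 25 percentage points lower from compound 1 to compound 2 (beyond the scatter), also took a methoxy group off this ring, yet the number fell, so the count of methoxy groups alone does not order the three compounds and this position responds strongly to how the ring is substituted. Nothing available explains why this change weakens the effect.

Going by these compounds, whether the rise comes from the methoxy group that remains or from the two that leave stays open, as both happen in one change. This ring carries only methoxy groups and hydrogen here, so how an amine or a carboxylic acid would read at this place is also unknown.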